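The compounds below may be only part of what the source reports. "The series", "measured", "known", "first", "only" and "open" are said of these compounds alone.

Measured so far in an assay on HEK293 cells for displacement of a labelled ligand from Neuronal acetylcholine receptor; alpha3/beta4 (Homo sapiens), read by scintillation counting, with a stated time of 120 min; a lower number here means a stronger inhibitor, a higher number a weaker inhibitor:
compound 1 `FCCCOc1cccc(-c2cn([C@H]3CN4CCC3CC4)nn2)c1` gives 1630 nM
compound 2 `c1ccc(COc2cccc(-c3cn([C@H]4CN5CCC4CC5)nn3)c2)cc1` gives 631 nM
compound 3 `Fc1cccc(-c2cn([C@H]3CN4CCC3CC4)nn2)c1` gives 362 nM

Compound 3 carries the lowest number of the three. The step in from its nearer neighbour is a 1.7-fold lower number from compound 2 to compound 3 (0.24 log units; within the scatter), so these two cannot be ordered against each other; the step in from its further neighbour is a 4.5-fold lower number from compound 1 to compound 3 (0.65 log units; beyond the scatter), which does separate them. The remaining measured step is a 2.6-fold lower number from compound 1 to compound 2 (0.41 log units; beyond the scatter).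

Compound 4 `Fc1ccc(COc2cccc(-c3cn([C@H]4CN5CCC4CC5)nn3)c2)cc1` differs from compound 3 in one place: (4-fluorobenzyl)oxy in place of fluoro on an aromatic carbon. The measured step that bears on this change is a 1.7-fold lower number from compound 2 to compound 3 (0.24 log units; within the scatter), in which a benzyloxy group gave way to fluoro with no separation beyond the scatter. For the measured compounds named here, compound 4 brings such a group back, now carrying a fluorine on its benzyl ring, a combination no measured pair covers directly. The expectation is therefore a step of about that size in the opposite direction, remaining within the scatter. For compound 4 the estimate in this assay is 650 nM, range 300 nM to 1600 nM, which corresponds to an expected step of a 1.8-fold higher number from compound 3 to compound 4 (0.25 log units; within the scatter).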

Compound 4, inhibition constant: 1090 nM
Beside the measured number, compound 4's estimate is 1.7-fold (0.22 log units) below it; low and high end bracket the measured number.
By their numbers in this assay, from the lowest: compounds 3, 2, 4 and 1 (each within the scatter of the next, the first and the last beyond it).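

In this assay, (4-fluorobenzyl)oxy on this aromatic carbon separates from fluoro (a 3.0-fold higher number from compound 3 to compound 4 (0.48 log units; beyond the scatter)), whereas the earlier benzyloxy comparison did not (a 1.7-fold lower number from compound 2 to compound 3 (0.24 log units; within the scatter)). Fluoro in place of hydrogen on the benzyl ring gives no separable step (a 1.7-fold higher number from compound 2 to compound 4 (0.24 log units; within the scatter)), and 4-fluorophenyl in place of 2-fluoroethyl on the chain carbon likewise stays unresolved (a 1.5-fold lower number from compound 1 to compound 4 (0.17 log units; within the scatter)), so compound 4 cannot be ordered against either compound 2 or compound 1. No available evidence accounts for these steps.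

From the compounds shown here alone, how an amine or a carboxylic acid on this aromatic carbon would compare with fluoro remains open. Also open, going by these compounds, is whether a nitrile or a methoxy group in place of the fluorine on the benzyl ring would give a step beyond the scatter.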